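From 1-(hydroxymethyl)cyclopropyl to 1-carboxyethyl on the amide

The compounds below may be only part of what the source reports. "The series", "measured", "known", "first", "only" and "open" are said of these compounds alone.

Values in a functional assay on MCF7 cells (Homo sapiens) for antiproliferative activity, read by MTT assay, with a stated time of 24 h; on this read-out lower numbers stand for stronger inhibition and higher numbers for weaker inhibition:
- Compound 1 `CCn1c(C(=O)N[C@H](C)C(=O)OC)ccc1C(CC)(CC)c1ccc(OCS(=O)(=O)c2ccccc2)c(C)c1`: > 50000 nM (a limit, not a number)
- Compound 2 `CCn1c(C(=O)N[C@H](C)CO)ccc1C(CC)(CC)c1ccc(OCS(=O)(=O)c2ccccc2)c(C)c1`: 10600 nM
- Compound 3 `CCn1c(C(=O)NC2(CO)CC2)ccc1C(CC)(CC)c1ccc(OCS(=O)(=O)c2ccccc2)c(C)c1`: 28800 nM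

Compound 3 has the higher of the two actual numbers, so it is the weaker of that pair: a 2.7-fold higher number from compound 2 to compound 3 (0.43 log units; beyond the scatter). Compound 4 `CCn1c(C(=O)N[C@@H](C)C(=O)O)ccc1C(CC)(CC)c1ccc(OCS(=O)(=O)c2ccccc2)c(C)c1` carries 1-carboxyethyl in place of 1-(hydroxymethyl)cyclopropyl on an amide-type nitrogen.

Within the data shown here, no measured step makes this exact swap. The closest evidence is an at least 4.7-fold lower number from compound 1 to compound 2 (0.67 log units; beyond the scatter) and an at least 1.7-fold lower number from compound 1 to compound 3 (0.23 log units; that floor lies within the scatter), although the floor of the second lies within the scatter. Both steps gain a hydroxymethyl group and lower the number. Read in reverse, they hint that losing it may raise the number, but no carboxyl group has been measured.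

In this assay, a small upward step is therefore expected, possibly within the scatter: a 1.5-fold higher number from compound 3 to compound 4 (0.16 log units; within the scatter). Compound 4 is estimated at 42000 nM, with an expected range from 15000 nM to 90000 nM. A result given only as a limit is also expected to be possible, as with the limit of > 50000 nM in this assay, at which 1 of the 3 values shown sits.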

Compound 4, half-maximal inhibitory concentration: 35500 nM
Compound 4: the middle estimate sits 1.2-fold (0.07 log units) above what was measured; measured number inside the range.
By their numbers in this assay, from the lowest: compound 2; then compounds 3 and 4 (each within the scatter of the next). At a limit, above all of these: compound 1.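

Among these compounds, compound 4 brings the first carboxyl group at this position on the amide-type nitrogen, and in this assay exchanging 1-(hydroxymethyl)cyclopropyl for 1-carboxyethyl makes no change beyond the scatter (a 1.2-fold higher number from compound 3 to compound 4 (0.09 log units; within the scatter)). On the open chain the comparison does separate, as the carboxyl compound has the higher number of the pair with the hydroxymethyl group (a 3.3-fold higher number from compound 2 to compound 4 (0.52 log units; beyond the scatter)), so among the open-chain compounds with actual numbers, the alcohol remains the stronger. Compound 1 is only a limit, so the step from the methyl ester gives just a floor that lies within the scatter (an at least 1.4-fold lower number from compound 1 to compound 4 (0.14 log units; that floor lies within the scatter)), and the ester and the acid cannot be ranked.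

The defined stereocentre of compound 4 is drawn with the opposite handedness to those of compounds 1 and 2, so the effect of handedness stays mixed into these steps. How a primary amide or an amine on the same chain would read is open.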